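The compounds below may be only part of what the source reports. "The series", "measured", "known", "first", "only" and "open" are said of these compounds alone.

Measured so far in an ADME assay on L6 cells (Rattus norvegicus) for cytotoxicity; a higher number here means a weaker inhibitor, a lower number a stronger inhibitor:
- compound 1 `COc1cc2c(cc1C(C)OCc1ccccc1)C=CC(C)(C)O2` gives 43900 nM
- compound 2 `COc1cc2c(cc1C(C)NCCCc1ccccc1)C=CC(C)(C)O2` gives 1080 nM
- compound 3 `COc1ccc(CNC(C)c2cc3c(cc2OC)OC(C)(C)C=C3)cc1` gives 14900 nM

Compound 1 has the highest number of the three, and both amines, compound 2 and compound 3, lie lower, beyond the scatter. Compound 4 `CCCCNC(C)c1cc2c(cc1OC)OC(C)(C)C=C2` is not yet measured. It differs from compound 1 as follows: butylamino in place of benzyloxy on a saturated chain carbon bound to an aromatic carbon and a saturated chain carbon. Among the compounds with values here, no butylamino compound has been measured, so the only guide is the large step between the two amines, a 14-fold higher number from compound 2 to compound 3 (1.14 log units; beyond the scatter), which shows how widely amines can differ here. Compound 4 is expected to fall with the amines, well under compound 1 in this assay. The estimated step is an 8.8-fold lower number from compound 1 to compound 4 (0.94 log units; beyond the scatter), large and toward a lower number. For compound 4 the estimated value is 5000 nM, with an expected range of 1500 nM to 17000 nM.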

Compound 4, half-maximal inhibitory concentration: 52500 nM
Compound 4: middle estimate off by 11-fold (1.02 log units), on the low side; measured number above the stated range.
By their numbers in this assay, from the lowest: compound 2; then compound 3; then compounds 1 and 4 (each within the scatter of the next).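

In this assay, an amine at this position does not by itself lower the number: butylamino in place of benzyloxy gives a 1.2-fold higher number from compound 1 to compound 4 (0.08 log units; within the scatter). Among the amines, the group on the chain matters, with a 3.5-fold higher number from compound 3 to compound 4 (0.55 log units; beyond the scatter) and a 49-fold higher number from compound 2 to compound 4 (1.69 log units; beyond the scatter), so compound 4, the amine without a ring, goes against any amine trend. Nothing measured here accounts for these differences. Still open, going by these compounds, is whether a longer chain such as hexyl would behave like butylamino, and whether a pyridine ring in place of the phenyl of compound 2 would keep its low number.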